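Replacing an Isopropyl Cap with a Methoxyphenyl Ring

A few compounds are considered here, and "the series" means these few. Any claim that something is new, unique, unknown or untested is made for them only; others in the source may bear on it.

Of the compounds shown here, three have been tested in a functional assay on HeLa cells (Homo sapiens) for antiproliferative activity, read by MTT assay, with a stated time of 72 h; a higher number here means a weaker inhibitor, a lower number a stronger inhibitor. Compound 1 `O=C1COc2ccc(-c3cccc(NS(=O)(=O)c4ccc(F)cc4)c3)cc2N1C1CC1` reaches only a limit of the assay, > 40000 nM. Compound 2 `O=C1COc2ccc(-c3cnc(Cl)c(NS(=O)(=O)c4ccc(F)cc4)c3)cc2N1C1CCCCC1` gives 14300 nM, while compound 3 `CC(C)N1C(=O)COc2ccc(-c3cnc(Cl)c(NS(=O)(=O)c4ccc(F)cc4)c3)cc21` gives 5380 nM, the lowest of the two numbers available. Among the measured compounds shown here, the only earlier change at this ring nitrogen produced a 2.7-fold lower number from compound 2 to compound 3 (0.42 log units; beyond the scatter), a modest shift. Compound 4 `COc1ccc(N2C(=O)COc3ccc(-c4cnc(Cl)c(NS(=O)(=O)c5ccc(F)cc5)c4)cc32)cc1` differs from compound 3 in one place: 4-methoxyphenyl in place of isopropyl on an amide-type nitrogen in a ring. For the measured compounds named here, no measured compound carries an aromatic group on that nitrogen, so the earlier step offers a size but not a direction for this new change. For compound 4 a step of about a 1.1-fold lower number from compound 3 to compound 4 (0.03 log units; within the scatter) is expected. Compound 4 is therefore estimated at 5000 nM, with a likely range from 1500 nM to 20000 nM.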

Compound 4, half-maximal inhibitory concentration: 8320 nM
For compound 4 the middle estimate is 1.7-fold (0.22 log units) below the measured one; the measured number falls inside the stated range.
By their numbers in this assay, from the lowest: compounds 3, 4 and 2 (each within the scatter of the next, the first and the last beyond it). At a limit, above all of these: compound 1.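

With 4-methoxyphenyl on the amide-type nitrogen, this assay shows a 1.5-fold higher number from compound 3 to compound 4 (0.19 log units; within the scatter) and also a 1.7-fold lower number from compound 2 to compound 4 (0.24 log units; within the scatter) in the same reading. An aromatic ring is therefore tolerated at this position, and compound 4 cannot be separated from either the isopropyl compound 3 or the cyclohexyl compound 2, although those two lie beyond the scatter of each other. Nothing shown bears on the reason for this result.

Open, going by these compounds, is whether an amine or a carboxylic acid on this phenyl ring, or a longer chain on the nitrogen, would shift the number beyond the scatter.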